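Adding chlorines to the aryl group of compound 1

The compounds below may be only part of what the source reports. "The series", "measured", "known", "first", "only" and "open" are said of these compounds alone.

In a functional assay on HCT-116 cells (Homo sapiens) for antiproliferative activity, read by MTT assay, with a stated time of 72 h (on this read-out lower numbers stand for stronger inhibition and higher numbers for weaker inhibition), compound 1 (`NC1=NC2(CCSCC2)N(OCCCOc2cccc(Cl)c2)C(N)=N1`) gives 1 nM as the lowest of the three numbers in hand. Compound 2 (`NC1=NC2(CCOCC2)N(OCCCOc2cccc(Cl)c2Cl)C(N)=N1`) gives 5 nM on the same read-out, and compound 3 (`Cc1cc(C)cc(OCCCON2C(N)=NC(N)=NC23CCOCC3)c1`) gives 190 nM there.

Compound 4 (`NC1=NC2(CCSCC2)N(OCCCOc2cc(Cl)c(Cl)cc2Cl)C(N)=N1`) keeps the core of compound 1 and carries 2,4,5-trichlorophenyl in place of 3-chlorophenyl on an oxygen on a saturated carbon.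

Within the data shown here, only one measured step bears on this place: 3,5-dimethylphenyl in place of 2,3-dichlorophenyl gives a 38-fold higher number from compound 2 to compound 3 (1.58 log units; beyond the scatter) as a warning that this group can move the number a long way. Among the measured compounds shown here, that step removes chlorine, however, and no measured step adds chlorine to the core of compound 1. Chlorine-bearing compound 2 stays low at 5 nM in this small set.

A modest rise is therefore expected, far smaller than the dimethyl step, and the estimated change is a 3.0-fold higher number from compound 1 to compound 4 (0.48 log units; beyond the scatter) in this assay as a working figure. Compound 4 is estimated at 3 nM with an expected range of 0.8 nM to 15 nM on this read-out.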

Compound 4, half-maximal inhibitory concentration: 1 nM
Compound 4: middle estimate off by 3.0-fold (0.48 log units), on the high side; the measured number falls inside the stated range.
By their numbers in this assay, from the lowest: compounds 1 and 4 (each within the scatter of the next); then compound 2; then compound 3.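

In this assay, 2,4,5-trichlorophenyl in place of 3-chlorophenyl on an oxygen on a saturated carbon gives no change at the digits printed from compound 1 to compound 4 (within the scatter), so on the core of compound 1 this place accepts the added chlorines with no visible cost. Among these compounds, the only earlier step at this place was a 38-fold higher number from compound 2 to compound 3 (1.58 log units; beyond the scatter), which showed how far the number can move; the new step shows that an exchange of aryl groups here can also leave it in place. Nothing in hand accounts for this result.

From the compounds shown here alone, whether the large rise seen with 3,5-dimethylphenyl carries over to the core of compound 1 remains open. Also open, going by these compounds, is how this place responds to an aryl group bearing an amine or a carboxylic acid, or to a longer chain carrying the aryl group.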